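This account rests on a few compounds, and the source may have more. Where it says the series, first, only, none or still open, it means among the compounds named here.

In a functional assay on HL-60 cells (Homo sapiens) for inhibition, read by MTT assay, with a stated time of 72 h (a lower number here means a stronger inhibitor, a higher number a weaker inhibitor), compound 1 `COc1cccc(N2CCN(C(=O)c3oc(C)nc3-c3ccccc3)CC2)c1`, which carries a methoxy group, gives 34.8 nM. Compound 2 `CC(=O)Nc1cccc(N2CCN(C(=O)c3oc(C)nc3-c3ccccc3)CC2)c1`, which carries an acetamido group in its place, gives 329 nM. Compound 2 therefore has the higher of the two numbers and is the weaker inhibitor of the pair, and the change between them is a 9.5-fold higher number from compound 1 to compound 2 (0.98 log units; beyond the scatter).

The next compound is compound 3 `Cc1nc(-c2ccccc2)c(C(=O)N2CCN(c3ccccc3)CC2)o1`, which has not yet been measured. It has hydrogen in place of acetamido on an aromatic carbon, leaving a plain phenyl: hydrogen in place of acetamido on an aromatic carbon.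

For the measured compounds named here, only one measured step bears on this change, and it concerns the same place on the same ring. Going by the values given here, no measured compound has hydrogen there, so the effect of removing the group is untested. Among the compounds with values here, compound 1, at 34.8 nM, shows only that the acetamido group is not needed for a low number. A move toward a lower number therefore seems more likely than not, though probably not all the way to the methoxy value.

The expected change is a 2.7-fold lower number from compound 2 to compound 3 (0.44 log units; beyond the scatter), an estimate with real uncertainty. For compound 3, the estimated value is 120 nM, with an expected range of 35 nM to 400 nM.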

Compound 3, half-maximal inhibitory concentration: 39.1 nM
Estimate against measurement, compound 3: 3.1-fold (0.49 log units) above; the measured number falls inside the stated range.
By their numbers in this assay, from the lowest: compounds 1 and 3 (each within the scatter of the next); then compound 2.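

In this assay the swap of acetamido for hydrogen gives an 8.4-fold lower number from compound 2 to compound 3 (0.93 log units; beyond the scatter) and shows directly what could only be inferred before: this place on the ring needs no group at all for a low number, and a plain phenyl is enough. The swap of methoxy for hydrogen gives a 1.1-fold higher number from compound 1 to compound 3 (0.05 log units; within the scatter) and so no difference can be read between these two groups here, which means the low number seen with methoxy does not depend on that group being present. Of the three groups seen at this place, only acetamido stands apart, and no further data are available to explain this.

Still open, from the compounds shown here alone, is whether acetamido is a lone case or one of many groups that go with a higher number here, and an amine, a carboxylic acid or a chlorine atom at the same carbon would help to settle that. Also open, going by these compounds, is whether the picture holds on the other carbons of this ring, as every group compared here sits meta to a large group.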